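Para Substituent on the Sulfonyl Ring: Fluoro to Cyano

This account rests on a few compounds, and the source may have more. Where it says the series, first, only, none or still open, it means among the compounds named here.

Measured compounds:
Compound 1 `O=C1/C(=C/c2ccc(F)cc2)CN(S(=O)(=O)c2ccc(C(F)(F)F)cc2)C/C1=C\c1ccc(F)cc1`: 4400 nM
Compound 2 `O=C1/C(=C/c2ccc(F)cc2)CN(S(=O)(=O)c2ccc(F)cc2)C/C1=C\c1ccc(F)cc1`: 14700 nM

Two compounds share a core in which one aromatic ring carries a sulfonyl group, and they differ only in the group on that ring. Going by the values given here, in a functional assay on SMMC-7721 cells (Homo sapiens) for cytotoxicity, read by MTT assay, with a stated time of 24 h (on this read-out higher numbers stand for weaker inhibition and lower numbers for stronger inhibition), compound 1 gives 4400 nM, and compound 2 gives 14700 nM, the highest of the two numbers; the only step is a 3.3-fold higher number from compound 1 to compound 2 (0.52 log units; beyond the scatter).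

Compound 3 `N#Cc1ccc(S(=O)(=O)N2C/C(=C\c3ccc(F)cc3)C(=O)/C(=C/c3ccc(F)cc3)C2)cc1` has not been measured. It differs from compound 2 by cyano in place of fluoro on an aromatic carbon. Among the compounds with values here, no measured step covers cyano at this position; the single step shows that swapping the group at this place moves the number by a modest amount, so a modest shift is expected for compound 3, in either direction, possibly within the scatter. Compound 3 is therefore estimated at 9000 nM, ranging from 3000 nM to 27000 nM, which means an expected step of a 1.6-fold lower number from compound 2 to compound 3 (0.21 log units; within the scatter).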

Compound 3, half-maximal inhibitory concentration: 15000 nM
Compound 3: middle estimate off by 1.7-fold (0.22 log units), on the low side; the range from low to high includes it.
By their numbers in this assay, from the lowest: compound 1; then compounds 2 and 3 (each within the scatter of the next).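

In this assay, cyano and fluoro cannot be told apart at this place on the aromatic ring that carries the sulfonyl group, with a 1.0-fold higher number from compound 2 to compound 3 (0.01 log units; within the scatter). Trifluoromethyl now stands apart from two different groups rather than one: replacing it with cyano gives a 3.4-fold higher number from compound 1 to compound 3 (0.53 log units; beyond the scatter), so among these three compounds, compound 1 is the most potent. Nothing available explains why trifluoromethyl stands apart from the other two groups.

The compounds shown leave open how an amine, a methoxy group or a carboxylic acid would read at this same place. They also leave open whether trifluoromethyl would keep its lead if the groups elsewhere on the shared core were changed.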